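A few compounds are considered here, and "the series" means these few. Any claim that something is new, unique, unknown or untested is made for them only; others in the source may bear on it.

In a physicochemical assay for lipophilicity, read by HPLC, measured as octanol-water partition (a lower number here means a more polar compound, a higher number a more lipophilic compound), compound 1 (`O=C(N/N=C/c1ccc2no[n+]([O-])c2c1)c1ccccc1O`) gives 1.3. Compound 2 (`NC(=O)c1c(COc2cccc(/C=N/NC(=O)c3ccncc3)c2)no[n+]1[O-]`) gives 1.3 and compound 3 (`NC(=O)c1c(COc2ccccc2/C=N/NC(=O)c2ccncc2)no[n+]1[O-]`) gives 1.3, so compound 1 stands level with both at the digits shown. Compound 4 (`Nc1ccc(C(=O)N/N=C/c2ccc3no[n+]([O-])c3c2)cc1`) keeps the core of compound 1 and carries 4-aminophenyl in place of 2-hydroxyphenyl on a carbonyl carbon. Among the measured compounds shown here, no pair of measured compounds differs in a single place, so the series gives no direct guide to the size of this step, and the estimate rests on the structural change alone. Expected here is a number 0.20 log units lower from compound 1 to compound 4 (within the scatter), a small downward step that stays within the scatter. In this assay the estimated value for compound 4 is 1.1, with an expected range of 0.7 to 1.5.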

Compound 4, partition coefficient: 1.2
Compound 4: middle estimate off by 0.10 log units, on the low side, and the stated range covers the measured number.
By their numbers in this assay, from the lowest: compounds 4, 1, 2 and 3 (each within the scatter of the next).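

In this assay, 4-aminophenyl in place of 2-hydroxyphenyl on a carbonyl carbon gives a number 0.10 log units lower from compound 1 to compound 4 (within the scatter), the first single-place step available in the series. At this position, the exchange of one substituted phenyl for the other therefore stays within the scatter. Nothing measured here gives a reason for this result.

Still open, as far as these compounds go, is whether the group or its place on the phenyl ring matters; 4-hydroxyphenyl and 2-aminophenyl would separate the two. A carboxylic acid or a longer alkyl chain on this carbonyl carbon also remains to be compared with compound 1 in this assay on the same core.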